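A chloro group added to the shared core

This account rests on a few compounds, and the source may have more. Where it says the series, first, only, none or still open, it means among the compounds named here.

Of the compounds shown here, three built on one shared core have been tested in a functional assay on the whole organism (strain Sprague-Dawley) for inhibition, with Rattus norvegicus as the target; a lower number here means that less compound is needed, a higher number that more compound is needed for the effect. Compound 3 `O=c1c(-c2nn[nH]n2)c[nH]c2ccccc12` carries only hydrogen on its carbon-only aromatic ring and gives 1.25 mg/kg, the lowest of the numbers shown. Compound 1 `COc1ccc2c(=O)c(-c3nn[nH]n3)c[nH]c2c1` carries a methoxy group on that ring and gives 10 mg/kg. Compound 2 `O=c1c(-c2nn[nH]n2)c[nH]c2c(Br)cccc12` carries a bromo group; in this assay compound 2 reaches only a limit, > 5 mg/kg, and no number. Both measured steps run toward compound 3: an 8.0-fold lower number from compound 1 to compound 3 (0.90 log units; beyond the scatter), and an at least 4.0-fold lower number from compound 2 to compound 3 (0.60 log units; beyond the scatter). In each case removing a substituent from the aromatic ring lowered the dose needed.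

Compound 4 `O=c1c(-c2nn[nH]n2)c[nH]c2ccc(Cl)cc12` goes the other way: chloro in place of hydrogen on an aromatic carbon. The chloro group enters at a different place from the methoxy of compound 1 and the bromo of compound 2, so neither measured step is a direct model for it. Still, both steps show that a substituent on this ring has so far meant a higher number, and the same direction is expected here, though tempered by the change of place. Compound 4 is therefore expected to need more than compound 3, with an expected step of a 2.0-fold higher number from compound 3 to compound 4 (0.30 log units; within the scatter). For compound 4 the estimate in this assay is 2.5 mg/kg, with a range from 1 mg/kg to 10 mg/kg.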

Compound 4, minimum effective dose: > 10 mg/kg
Compound 4: a limit, no number; the forecaster's own chance of this, stated with the estimate: 15%; at least 4.0-fold (0.60 log units) between middle value and limit.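

In this assay, putting one chlorine atom in place of hydrogen, on an aromatic carbon meta to a fused ring and para to a fused ring, gives an at least 8.0-fold higher number from compound 3 to compound 4 (0.90 log units; beyond the scatter). The higher dose seen with the methoxy of compound 1 and the bromo of compound 2 is therefore not confined to their places on the ring: all three substituted compounds need more than compound 3, and none of the four goes against this. The true size of the step remains unknown because compound 4 reaches only a limit of the assay, not a number: the limit of > 10 mg/kg in this assay, at which 1 of the 4 values shown sits.

Chloro is the only group shown at this place, so it remains open whether a fluoro, a methyl, an amine or a carboxylic acid there would bring the dose back towards that of compound 3 in this assay. Equally open, as far as these compounds go, is how far the dose depends on the other parts of the shared core, which stay the same in all four compounds.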